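The source may report more compounds than this note shows. Statements on the series, on what has been measured and on what is new or still open speak of the compounds shown alone.

Working notes on the series. In a toxicity assay on HeLa cells (Homo sapiens) for cytotoxicity, read by MTT assay, with a stated time of 24 h (a higher number here means a weaker inhibitor, a lower number a stronger inhibitor), compound 2 `Cc1ncc([N+](=O)[O-])n1CC(O)CSC(=S)N1CCOCC1` gives 4520000 nM, the higher of the two numbers in hand. Compound 1 `Cc1ncc([N+](=O)[O-])n1CC(O)CSC(=S)N1CCN(c2cccc(Cl)c2Cl)CC1` gives 1000000 nM in this assay, a lower number, beyond the scatter. Compound 3 `CCN(C)C(=S)SCC(O)Cn1c([N+](=O)[O-])cnc1C` differs from compound 2 by ethyl(methyl)amino in place of morpholin-4-yl on a thiocarbonyl carbon. Within the data shown here, no measured pair covers this change, so its effect in this assay is unknown; with both numbers in hand at very weak inhibition, no step beyond the scatter is expected in either direction. For compound 3 in this assay the estimate is 3000000 nM, within 800000 nM to 10000000 nM, an expected step of a 1.5-fold lower number from compound 2 to compound 3 (0.18 log units; within the scatter).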

Compound 3, half-maximal inhibitory concentration: 4150000 nM
Estimate against measurement, compound 3: 1.4-fold (0.14 log units) below; the measured number falls inside the stated range.
By their numbers in this assay, from the lowest: compound 1; then compounds 3 and 2 (each within the scatter of the next).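

In this assay, ethyl(methyl)amino in place of morpholin-4-yl on a thiocarbonyl carbon gives a 1.1-fold lower number from compound 2 to compound 3 (0.04 log units; within the scatter), the first step measured at this position. For this pair, the six-membered ring and its oxygen can give way to an open-chain group without a change beyond the scatter. No measurement in hand bears on a cause for this result.

From the compounds shown here alone, whether this tolerance extends to a longer chain such as dibutylamino, or to a piperidine ring without the oxygen, remains open. Going by these compounds, the effect of a carboxylic acid on the chain also remains open.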